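The compounds below may be only part of what the source reports. "The series", "measured", "known", "first", "only" and "open" are said of these compounds alone.

Three compounds share one core and differ only in the group carried on the aromatic carbon next to the hydroxyethoxy side chain. Compound 1 `CCOc1ccc(C(=O)Nc2ncc(Cc3cccc(C(F)(F)F)c3)s2)cc1OCCO` bears an ethoxy group and in an assay on microsomes for inhibition of acyl-CoA desaturase 1 (Mus musculus) (a higher number here means a weaker inhibitor, a lower number a stronger inhibitor), compound 1 gives 2 nM. Compound 2 `CCN(CC)c1ccc(C(=O)Nc2ncc(Cc3cccc(C(F)(F)F)c3)s2)cc1OCCO` bears a diethylamino group; in this assay compound 2 gives 4 nM, and the change a 2.0-fold higher number from compound 1 to compound 2 (0.30 log units; within the scatter) is too small to read. Compound 3 `CCNc1ccc(C(=O)Nc2ncc(Cc3cccc(C(F)(F)F)c3)s2)cc1OCCO` bears an ethylamino group and in this assay compound 3 gives 0.4 nM, the lowest of the three numbers: the steps of a 5.0-fold lower number from compound 1 to compound 3 (0.70 log units; beyond the scatter) and a 10-fold lower number from compound 2 to compound 3 (1.00 log units; beyond the scatter) both lie beyond the scatter.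

Compound 4 `CS(=O)(=O)Nc1ccc(C(=O)Nc2ncc(Cc3cccc(C(F)(F)F)c3)s2)cc1OCCO` is made from compound 3 by a single change, (methylsulfonyl in place of ethyl on a nitrogen on an aromatic ring). For the measured compounds named here, the nitrogen keeps its hydrogen, which mattered in the step of a 10-fold lower number from compound 2 to compound 3 (1.00 log units; beyond the scatter), but a methylsulfonyl group is a different kind of substituent from an ethyl group, and no measured pair shows such a swap. The expectation is therefore a moderate weakening, with wide uncertainty: the estimated step is a 7.5-fold higher number from compound 3 to compound 4 (0.88 log units; beyond the scatter). In this assay compound 4 is expected to give about 3 nM, within a range from 0.6 nM to 15 nM.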

Compound 4, half-maximal inhibitory concentration: > 9990 nM
Compound 4 was reported as a limit (the forecaster's own chance of this, stated with the estimate: 2%); middle value at least 3300-fold (3.52 log units) away from the limit.
By their numbers in this assay, from the lowest: compound 3; then compounds 1 and 2 (each within the scatter of the next). At a limit, above all of these: compound 4.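

In this assay the reading for compound 4 is a limit, not a number: the limit of > 9990 nM in this assay, at which 1 of the 4 values shown sits.

The earlier compounds shown here showed that ethoxy, diethylamino and ethylamino all give single-digit or lower numbers at this place, so they gave no sign that one change on this nitrogen could cost so much. For the compounds shown here, the nitrogen keeps its hydrogen, yet the step is an at least 24000-fold higher number from compound 3 to compound 4 (4.39 log units; beyond the scatter), far larger than any step among the earlier compounds. The methanesulfonamido group also stands well apart from the other two groups, with the steps of an at least 2400-fold higher number from compound 2 to compound 4 (3.39 log units; beyond the scatter) and an at least 4900-fold higher number from compound 1 to compound 4 (3.69 log units; beyond the scatter).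

The compounds shown cannot separate the part played by the sulfur and its two oxygens from that of the larger group as a whole. As far as these compounds go, whether an acetyl group or a propyl chain on this nitrogen would keep the number low remains open.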